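The source may report more compounds than this note shows. Statements on the series, on what has been measured and on what is new or still open speak of the compounds shown alone.

Compound 1, `O=C(COc1ccc(/C=C2\SC(=O)NC2=O)cc1)Nc1cccc([N+](=O)[O-])c1`: in a functional assay on PC-3 cells (Homo sapiens) for inhibition (on this read-out higher numbers stand for weaker inhibition of growth and lower numbers for stronger inhibition of growth), compound 1 gives > 100000 nM, which is a limit of the assay and not a number.
Compound 2, `O=C(COc1ccc(/C=C2\SC(=O)NC2=O)cc1)Nc1ccc(Cl)cc1`: in this assay compound 2 gives 83400 nM.
Compound 3, `Cc1ccc(NC(=O)COc2ccc(/C=C3\SC(=O)NC3=O)cc2)cc1Cl`: in this assay compound 3 gives > 100000 nM, again a limit and not a number.

For the measured compounds named here, compound 2 thus stands as the only compound of the three with a number in this assay; the two others sit at the limit of > 100000 nM in this assay, at which 2 of the 3 values shown sit. Compound 4, `O=C(COc1ccc(/C=C2\SC(=O)NC2=O)cc1)Nc1ccc(Cl)cc1C(F)(F)F`, differs from compound 2 by trifluoromethyl in place of hydrogen on an aromatic carbon. Of the measured steps, only those touching compound 2 bear on this: an at least 1.1-fold lower number from compound 1 to compound 2 (0.07 log units; that floor lies within the scatter) and an at least 1.1-fold higher number from compound 2 to compound 3 (0.07 log units; that floor lies within the scatter). Both are small on their readable side and both run against limits, so they say little beyond placing compound 2 near the limit. For compound 4 the step is therefore expected to be a 1.2-fold higher number from compound 2 to compound 4 (0.08 log units; within the scatter), nothing beyond the scatter. The estimate for compound 4 is 100000 nM, with a range from 40000 nM to 250000 nM.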

Compound 4, concentration for 50% growth inhibition: > 100000 nM
Compound 4: no number, only a limit; the forecaster's own chance of this, stated with the estimate: 55%; the middle value lies on the limit itself.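

Trifluoromethyl in place of hydrogen on an aromatic carbon, ortho to a large group and meta to a chloro group, is the first change shown at this place on the ring, and in this assay it gives an at least 1.1-fold higher number from compound 2 to compound 4 (0.07 log units; that floor lies within the scatter). In this assay compound 4 gives > 100000 nM, which is a limit of the assay and not a number. The change therefore yields no readable gain, and compound 2 remains the only compound with a number: the limit of > 100000 nM in this assay, at which 3 of the 4 values shown sit.

Since the step has only a floor, the compounds shown leave open whether trifluoromethyl here truly raises the number or leaves it within the scatter. Also open, on these data alone, is what a methyl, an amine or a carboxylic acid at this same place would give in this assay.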